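The compounds below may be only part of what the source reports. "The series", "measured", "known", "first", "only" and "open" are said of these compounds alone.

Measured so far in an assay on HeLa cells for inhibition of sphingosine-1-phosphate transporter SPNS2 (Mus musculus), read by LC-MS, tested at 2 uM; a lower number here means less inhibition, a higher number more inhibition at the concentration tested (going by the name of the read-out):
compound 1 `CCCCCCCCCCc1ccc(-c2noc(CCCCN)n2)cc1` gives 55%
compound 2 `CCCCCCCCCCc1ccc(-c2noc(CC3CNC3)n2)cc1` gives 63%
compound 3 `CCCCCCCCCCc1ccc(-c2noc([C@@H]3CCNC3)n2)cc1` gives 62%

Compound 3 stands second highest of the three numbers. Its nearest neighbour is compound 2, with a number 1 percentage points lower from compound 2 to compound 3 (within the scatter); its furthest is compound 1, with a number 7 percentage points higher from compound 1 to compound 3 (within the scatter). All three values sit within the usual scatter of one another, so no order among them can be read.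

Compound 4 `CCCCCCCCCCc1ccc(-c2noc(CCCN3CCCCC3)n2)cc1` differs from compound 3 in one place: 3-(piperidin-1-yl)propyl in place of pyrrolidin-3-yl on an aromatic carbon

Going by the values given here, two measured steps bear on this position. Both a number 8 percentage points higher from compound 1 to compound 2 (within the scatter) and a number 7 percentage points higher from compound 1 to compound 3 (within the scatter) exchanged one amine-bearing group for another on the same carbon of the shared core, and neither moved the read-out beyond the scatter. Among the compounds with values here, those steps went from an open chain to a ring; the present step goes from a ring to a chain that carries a ring, and no measured pair covers a group of this kind. Given that every exchange seen so far at this position stayed within the scatter, the step of a number 2 percentage points lower from compound 3 to compound 4 (within the scatter) is expected to be small and in no particular direction. Compound 4 is therefore estimated at 60%, with a range of 44% to 76%.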

Compound 4, a percentage reported as inhibition, at one concentration (the size of the read-out at that concentration, not a potency): 0%
Compound 4: the middle estimate sits 60 percentage points above what was measured; measured number outside the range, below it.
By their numbers in this assay, from the lowest: compound 4; then compounds 1, 3 and 2 (each within the scatter of the next).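

In this assay, going by these compounds alone, this position, on an aromatic carbon of the five-membered aromatic ring, proves not to accept every amine-bearing group: the exchange for the group of compound 4 gives the first steps here beyond the scatter (a number 62 percentage points lower from compound 3 to compound 4 (beyond the scatter)), (a number 63 percentage points lower from compound 2 to compound 4 (beyond the scatter)) and (a number 55 percentage points lower from compound 1 to compound 4 (beyond the scatter)), while the groups of compounds 1, 2 and 3 remain within the scatter of one another. A ring nitrogen alone is therefore not enough to hold the read-out, since 3-(piperidin-1-yl)propyl also has one, but this change also replaces 5 heavy atoms and 1 hydrogen-bond donor in pyrrolidin-3-yl with 9 heavy atoms and 0 hydrogen-bond donors, and these differences travel together. No measurement at hand accounts for the loss.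

Still open, going by these compounds, is which of these differences goes with the loss: 1-methylpyrrolidin-3-yl would change the donor count with little change in size, whereas 3-(piperidin-4-yl)propyl would keep the larger chain-and-ring group with a ring amine hydrogen. A shorter piperidin-1-ylmethyl group would further show whether the length of the chain matters.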